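Straight chain in place of branched chain at an amine nitrogen

The source may hold more compounds than are shown below. What is called first, only, known or untested is meant among the compounds shown, and "the series" means these compounds.

Two compounds measured in a functional assay on CCRF-CEM cells for antagonist activity at C-X-C chemokine receptor type 4 (Homo sapiens), read by calcium flux, with stated times of 25 min and 90 s (on this read-out higher numbers stand for weaker inhibition and lower numbers for stronger inhibition), share one core and differ only in the group on an amine nitrogen. Compound 1 `FC1(F)CCC(CN(C[C@H]2Cc3c(cccc3N3CCNCC3)CN2)[C@H]2CCCc3cccnc32)CC1` gives 498 nM. Compound 2 `CC(C)N(C[C@H]1Cc2c(cccc2N2CCNCC2)CN1)[C@H]1CCCc2cccnc21` gives 364 nM; this is the lowest of the two numbers, but the step of a 1.4-fold lower number from compound 1 to compound 2 (0.14 log units; within the scatter) lies within the scatter, so the two compounds cannot be ranked against each other. Compound 3 `CCCN(C[C@H]1Cc2c(cccc2N2CCNCC2)CN1)[C@H]1CCCc2cccnc21` has not yet been measured. It differs from compound 2 by propyl in place of isopropyl on an amine nitrogen, the same atoms joined differently. Among the compounds with values here, the one measured step at this nitrogen exchanged a far larger group and still stayed within the scatter, so a small rearrangement of the same three carbons is expected to give a step of a 1.1-fold higher number from compound 2 to compound 3 (0.04 log units; within the scatter) in this assay, nothing beyond the scatter. Compound 3 is therefore estimated at 400 nM, with a likely range from 150 nM to 1100 nM.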

Compound 3, half-maximal inhibitory concentration: 32.2 nM
The estimate for compound 3 lay 12-fold (1.09 log units) above the measured number; the whole stated range lies above it.
By their numbers in this assay, from the lowest: compound 3; then compounds 2 and 1 (each within the scatter of the next).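

In this assay, this amine nitrogen proves sensitive to how its three chain carbons are joined: with no atom gained or lost, propyl in place of isopropyl gives an 11-fold lower number from compound 2 to compound 3 (1.05 log units; beyond the scatter). The earlier pair could not show this, as its much larger exchange stayed within the scatter, yet propyl also stands clear of the (4,4-difluorocyclohexyl)methyl group, with a 15-fold lower number from compound 1 to compound 3 (1.19 log units; beyond the scatter). Nothing available here explains why propyl and isopropyl differ so widely.

On these data alone, it remains open whether the low number depends on this exact chain length or simply on an unbranched chain, a question that ethyl or butyl at this nitrogen would address. An amine at the end of the propyl chain would show whether the chain's far end can carry a further group.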